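Estimating Cytotoxicity for a Fourth Compound in the Series

The source may hold more compounds than are shown below. What is called first, only, known or untested is meant among the compounds shown, and "the series" means these compounds.

Compound 1 `N/C(=N\O)c1ccc(C(=O)CS(=O)(=O)c2ccc(/C(N)=N/O)cc2)cc1` gives > 125000 nM in an ADME assay on THP-1 cells (Homo sapiens) for cytotoxicity, read by flow cytometry, with a stated time of 72 h; a higher number here means a weaker inhibitor, a lower number a stronger inhibitor; this value is a limit of the assay, not a number.
Compound 2 `N/C(=N\O)c1ccc(C2=C(S(=O)(=O)c3ccccc3)CC(c3ccccc3)(c3ccccc3)O2)cc1` gives 30600 nM in this assay.
Compound 3 `N/C(=N\O)c1ccc(S(=O)(=O)C2=C(c3ccccc3)OC(c3ccccc3)(c3ccccc3)C2)cc1` gives 37900 nM in this assay.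

Compound 3 holds the highest of the two numbers shown, but its nearest neighbour, compound 2, lies within the usual scatter of it, so the two stand level. Compound 1 sits at the limit of > 125000 nM in this assay, at which 1 of the 3 values shown sits.

Compound 4 `N/C(=N\O)c1ccc(C2=C(S(=O)(=O)c3ccc(/C(N)=N/O)cc3)CC(c3ccccc3)(c3ccccc3)O2)cc1` differs from compound 3 by a group of 4 heavy atoms (1 carbon, 2 nitrogen, 1 oxygen; no ring) in place of a hydrogen atom, on an aromatic carbon. Among the compounds with values here, no pair of measured compounds shows this change on its own, so the size of the step is not known from measurement. Within the data shown here, compound 1 carries the entering group twice and is the one compound that reaches the limit. On that basis compound 4 is expected to move toward a higher number, a modest step that may reach beyond the scatter, with a real chance that only a limit is reported. The expected step is a 1.7-fold higher number from compound 3 to compound 4 (0.23 log units; within the scatter). Compound 4 is estimated at 65000 nM, within 25000 nM to 160000 nM.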

Compound 4, half-maximal inhibitory concentration: 119000 nM
Estimate against measurement, compound 4: 1.8-fold (0.26 log units) below, within the range that was stated.
By their numbers in this assay, from the lowest: compounds 2 and 3 (each within the scatter of the next); then compound 4. At a limit, above all of these: compound 1.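

Adding the group of 4 heavy atoms on an aromatic carbon, para to a large group, now has a measured size in this assay: a 3.1-fold higher number from compound 3 to compound 4 (0.50 log units; beyond the scatter), and a 3.9-fold higher number from compound 2 to compound 4 (0.59 log units; beyond the scatter). Compound 2 and compound 3 stand level, so both steps point the same way: with this group in place of a hydrogen atom, compound 4 is a weaker inhibitor than either of them. Compound 1 also carries this group, twice, and its value is a limit of the assay, not a number: the limit of > 125000 nM in this assay, at which 1 of the 4 values shown sits.

The compounds shown leave open whether the same group would give a step of this size on a different carbon of that ring. Also open, going by these compounds, is how far a smaller group, such as an amine or a carboxylic acid, would move the number from the same place.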